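The source may hold more compounds than are shown below. What is called first, only, known or untested is meant among the compounds shown, and "the series" means these compounds.

Working notes on a set of thioether analogues built on one shared core and compared in an ADME assay on cells (Mus musculus, strain BALB/c) for cytotoxicity, read by MTT assay, with a stated time of 24 h; a higher number here means that more compound is tolerated, a lower number that less compound is tolerated. Compound 1 `COc1cc(-c2nnc(SCc3ccc([N+](=O)[O-])cc3)o2)ccc1O` gives 688000 nM in this assay. Compound 2 `COc1cc(-c2nnc(SCc3ccc(C)cc3)o2)ccc1O` gives 549000 nM in this assay. Compound 3 `COc1cc(-c2nnc(SCc3cccc([N+](=O)[O-])c3)o2)ccc1O` gives 392000 nM in this assay. Compound 2 stands second highest of the three numbers: its nearest neighbour is compound 1, a gap within the scatter, and its furthest is compound 3, also within the scatter. Among the measured compounds shown here, the one single-point step measured so far, a 1.3-fold lower number from compound 1 to compound 2 (0.10 log units; within the scatter), is the only direct comparison among the three and stays inside the scatter.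

The next compound, compound 4 `COc1cc(-c2nnc(SCc3c(F)cccc3F)o2)ccc1O`, differs from compound 2 in one place: 2,6-difluorophenyl in place of 4-methylphenyl on a saturated chain carbon bound to a sulfur. For the measured compounds named here, no measured step covers this exact exchange of the whole ring. Going by the values given here, the only step available, a 1.3-fold lower number from compound 1 to compound 2 (0.10 log units; within the scatter), shows that swapping one substituent for another on an aromatic carbon of that ring left the number essentially unchanged, and the whole spread across compounds 1, 2 and 3 lies within the scatter. On that basis no step beyond the scatter is expected in this assay in either direction, the estimated step being a 1.1-fold lower number from compound 2 to compound 4 (0.04 log units; within the scatter). Compound 4 is accordingly expected to give about 500000 nM in this assay, with an estimated range from 250000 nM to 1000000 nM.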

Compound 4, half-maximal cytotoxic concentration: 575000 nM
Estimate against measurement, compound 4: 1.2-fold (0.06 log units) below, within the range that was stated.
By their numbers in this assay, from the lowest: compounds 3, 2, 4 and 1 (each within the scatter of the next).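

In this assay, the exchange of 4-methylphenyl for 2,6-difluorophenyl on a saturated chain carbon bound to a sulfur comes out as a 1.0-fold higher number from compound 2 to compound 4 (0.02 log units; within the scatter), so the replacement of the entire ring at this place stays within the scatter, as the earlier exchange of a single substituent on that ring did with a 1.3-fold lower number from compound 1 to compound 2 (0.10 log units; within the scatter). The change tested here is narrow in its counted features: both groups are one six-membered aromatic ring of carbon only, with no hydrogen-bond donors, no hydrogen-bond acceptors and no net charge, so the result covers the swap of methyl-bearing for fluorine-bearing rings of that kind and nothing wider. No supporting measurement bears on why the number holds across this exchange.

All the compounds shown keep that kind of uncharged aromatic carbon ring at this place, and none stands beyond the scatter of another by any printed step, so the range of groups tolerated here in this assay has no visible edge yet. On these data alone, whether a basic amine or a carboxylic acid on the ring, or a longer chain in place of the single saturated carbon bound to the sulfur, would move the number beyond the scatter stays open.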